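A few compounds are considered here, and "the series" means these few. Any claim that something is new, unique, unknown or untested is made for them only; others in the source may bear on it.

Measured so far:
compound 1, `CC(C)(C)N(NC(=O)c1ccccc1I)C(=O)c1ccccc1Cl`: 1290 nM
compound 2, `CC(C)(C)N(NC(=O)c1ccc(I)cc1)C(=O)c1ccccc1Cl`: 7.59 nM

Compound 1 gives the highest of the two numbers in an assay on cells for agonist activity at ecdysone receptor (Bombyx mori), read by a luciferase reporter, with a stated time of 24 h; a higher number here means that more compound is needed for the effect, a lower number that less compound is needed; compound 2 sits far lower, with a 170-fold lower number from compound 1 to compound 2 (2.23 log units; beyond the scatter). Compound 3, `Cc1ccc(C(=O)NN(C(=O)c2ccccc2Cl)C(C)(C)C)cc1C`, is not yet measured. It differs from compound 1 by 3,4-dimethylphenyl in place of 2-iodophenyl on a carbonyl carbon.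

Within the data shown here, only one measured step bears on this change. It exchanged 2-iodophenyl for 4-iodophenyl on the same carbonyl carbon and gave a 170-fold lower number from compound 1 to compound 2 (2.23 log units; beyond the scatter), a large drop well beyond the scatter. The move to compound 3 also leaves 2-iodophenyl behind, and the entering 3,4-dimethylphenyl likewise carries its substituents away from the position that 2-iodophenyl occupied. Among the measured compounds shown here, the step to compound 3 is therefore expected to point the same way as the step from compound 1 to compound 2, though no measured pair tells how far a 3,4-dimethylphenyl reaches.

For compound 3 a value of 20 nM is estimated, within 3 nM to 150 nM, i.e. an expected step of a 65-fold lower number from compound 1 to compound 3 (1.81 log units; beyond the scatter).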

Compound 3, half-maximal effective concentration: 87.1 nM
Estimate against measurement, compound 3: 4.4-fold (0.64 log units) below; the range from low to high includes it.
By their numbers in this assay, from the lowest: compound 2; then compound 3; then compound 1.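

In this assay, the change to 3,4-dimethylphenyl gives a 15-fold lower number from compound 1 to compound 3 (1.17 log units; beyond the scatter), so a large drop on leaving 2-iodophenyl is not confined to 4-iodophenyl as the entering group. The two groups that replace 2-iodophenyl also differ from each other, with an 11-fold higher number from compound 2 to compound 3 (1.06 log units; beyond the scatter), so the value at this position depends on the entering group and not only on the loss of 2-iodophenyl. No measurement at hand accounts for either step.

Going by these compounds, whether one methyl group alone would give the same result as the two in 3,4-dimethylphenyl remains open. Also open, on these data alone, is how an amine, a carboxylic acid or a methoxy group would compare with these groups on the phenyl ring at this carbonyl carbon.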